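Adding Two Hydroxyls to the Phenyl of Compound 3

The compounds below may be only part of what the source reports. "The series", "measured", "known", "first", "only" and "open" are said of these compounds alone.

Three measured compounds share one core and differ only in the group on a carbon with a double bond to nitrogen. Compound 1 `CN(C)CCn1cnnc1-c1cc(Oc2ccc(NC(=O)N/N=C/c3c[nH]c4ccccc34)cc2F)ccn1` carries 1H-indol-3-yl there, and in a functional assay on U-87MG ATCC cells (Homo sapiens) for cytotoxicity, read by MTT assay, with a stated time of 72 h (on this read-out lower numbers stand for stronger inhibition and higher numbers for weaker inhibition), compound 1 gives 690 nM. Compound 2 `CN(C)CCn1cnnc1-c1cc(Oc2ccc(NC(=O)N/N=C/c3ccccc3O[N+](=O)[O-])cc2F)ccn1` carries 2-(nitrooxy)phenyl and gives 7150 nM. Compound 3 `CN(C)CCn1cnnc1-c1cc(Oc2ccc(NC(=O)N/N=C/c3ccccc3)cc2F)ccn1` carries plain phenyl and gives 2250 nM, the second highest of the three numbers: a 3.3-fold higher number from compound 1 to compound 3 (0.51 log units; beyond the scatter), while a 3.2-fold lower number from compound 2 to compound 3 (0.50 log units; beyond the scatter). Compound 4 `CN(C)CCn1cnnc1-c1cc(Oc2ccc(NC(=O)N/N=C/c3ccc(O)cc3O)cc2F)ccn1` differs from compound 3 by 2,4-dihydroxyphenyl in place of phenyl on a carbon with a double bond to nitrogen. The step of a 3.2-fold lower number from compound 2 to compound 3 (0.50 log units; beyond the scatter) shows a group on this phenyl can shift the number modestly, and compound 1 gives the lowest number. A modest lowering is therefore expected, a 1.9-fold lower number from compound 3 to compound 4 (0.27 log units; within the scatter). Compound 4 is estimated at 1200 nM, within 400 nM to 3600 nM.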

Compound 4, half-maximal inhibitory concentration: 15400 nM
The estimate for compound 4 lay 13-fold (1.11 log units) below the measured number; the measured number lies above the stated range.
By their numbers in this assay, from the lowest: compound 1; then compound 3; then compound 2; then compound 4.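

Replacing phenyl with 2,4-dihydroxyphenyl on this carbon weakens inhibition instead of strengthening it (a 6.8-fold higher number from compound 3 to compound 4 (0.84 log units; beyond the scatter)). Compound 4 also sits above the other substituted phenyl (a 2.2-fold higher number from compound 2 to compound 4 (0.33 log units; beyond the scatter)) and far above the indole (a 22-fold higher number from compound 1 to compound 4 (1.35 log units; beyond the scatter)), giving the highest number of the four. Both substituted phenyls shown therefore give higher numbers than plain phenyl, so adding groups to this ring has not yet lowered the number.

Nothing available bears on why the number rises. On these data alone, whether a single hydroxyl, a methoxy or an amine on the phenyl would also raise the number remains open.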